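From 4-bromophenyl to 4-ethoxyphenyl on the shared core

The source may report more compounds than this note shows. Statements on the series, on what has been measured and on what is new or still open speak of the compounds shown alone.

Measured in a functional assay on MCF7 cells (Homo sapiens) for inhibition, read by sulforhodamine B assay; on this read-out higher numbers stand for weaker inhibition and lower numbers for stronger inhibition:
- compound 1 `O=C1C=C(NC2CCCCC2)C(=O)c2c1nc1n2[C@H]2OC[C@@H](O)[C@H]2OC1`: > 8000 nM (a limit)
- compound 2 `COc1ccccc1NC1=CC(=O)c2nc3n(c2C1=O)[C@H]1OC[C@@H](O)[C@H]1OC3`: > 4000 nM (a limit)
- compound 3 `O=C1C=C(Nc2ccc(Br)cc2)C(=O)c2c1nc1n2[C@H]2OC[C@@H](O)[C@H]2OC1`: 2580 nM

Within the data shown here, compound 3 gives 2580 nM, the only actual number among the three. The other two values are limits. Compound 4 `CCOc1ccc(NC2=CC(=O)c3nc4n(c3C2=O)[C@H]2OC[C@@H](O)[C@H]2OC4)cc1` keeps the shared core and differs from compound 3 in one place: ethoxy in place of bromo on an aromatic carbon. This is ethoxy in place of bromo on an aromatic carbon, para to a large group.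

Among the measured compounds shown here, no measured step changes this substituent alone, so the evidence is indirect. Replacing cyclohexyl with 4-bromophenyl on the amine nitrogen gives an at least 3.1-fold lower number from compound 1 to compound 3 (0.49 log units; beyond the scatter). Replacing 2-methoxyphenyl with 4-bromophenyl gives an at least 1.5-fold lower number from compound 2 to compound 3 (0.19 log units; that floor lies within the scatter). For the measured compounds named here, compound 2 is the only measured compound with an oxygen-linked group on its aromatic ring, and that second step offers only a weak hint. In this assay, a small move toward a higher number is therefore expected, possibly none beyond the scatter. The expected change is a 1.4-fold higher number from compound 3 to compound 4 (0.13 log units; within the scatter). Compound 4 is estimated at 3500 nM, with an expected range from 1500 nM to 8000 nM.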

Compound 4, half-maximal inhibitory concentration: 1430 nM
The estimate for compound 4 lay 2.4-fold (0.39 log units) above the measured number, and the stated range ends above it.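

Ethoxy in place of bromo, on an aromatic carbon para to a large group, gives a 1.8-fold lower number from compound 3 to compound 4 (0.26 log units; within the scatter) in this assay, so as far as these two compounds go, an oxygen-linked group at this position reads the same as bromo. The 4-ethoxyphenyl group also gives an at least 2.7-fold lower number from compound 2 to compound 4 (0.44 log units; beyond the scatter), which clears the scatter where the step from that compound to the 4-bromophenyl compound did not, and it gives an at least 5.5-fold lower number from compound 1 to compound 4 (0.74 log units; beyond the scatter). Compound 2 stands at a limit, so the step from it is only a floor: the limit of > 4000 nM in this assay, at which 1 of the 4 values shown sits.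

On these data alone, what methoxy, a longer chain such as butoxy, an amine or a carboxylic acid would do at this position stays open. As far as these compounds go, it also stays open how compound 1 and compound 2 compare, as their two limits cannot be read against each other.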